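The source may report more compounds than this note shows. Statements on the series, on what has been measured and on what is new or still open speak of the compounds shown alone.

In a functional assay on HepG2 cells (Homo sapiens) for antiproliferative activity, read by MTT assay, with a stated time of 24 h (on this read-out higher numbers stand for weaker inhibition and lower numbers for stronger inhibition), compound 1 `COc1ccc(S(=O)(=O)n2c(-c3cn(-c4ccccc4)nc3-c3ccc(F)cc3)nc3ccccc32)cc1` gives 470 nM and compound 2 `O=S(=O)(c1ccccc1)n1c(-c2cn(-c3ccccc3)nc2-c2ccc(C(F)(F)F)cc2)nc2ccccc21` gives 590 nM. Compound 2 therefore stands within the scatter of compound 1, and these two numbers set no order between them. Going by the values given here, the series offers no measured pair that differs in one place, so the size of a single change in this assay remains unmeasured.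

Compound 3 `COc1ccc(S(=O)(=O)n2c(-c3cn(-c4ccccc4)nc3-c3ccc(C(F)(F)F)cc3)nc3ccccc32)cc1` differs from compound 2 by one change: methoxy in place of hydrogen on an aromatic carbon. This places methoxy in place of hydrogen on an aromatic carbon, para to a large group, and turns phenylsulfonyl into (4-methoxyphenyl)sulfonyl. Among the compounds with values here, the only guide is compound 1, which already carries (4-methoxyphenyl)sulfonyl and gives 470 nM, within the scatter of the value for compound 2. No step beyond the scatter is therefore expected in this assay, and no direction is favoured. The estimated step is a 1.1-fold lower number from compound 2 to compound 3 (0.05 log units; within the scatter). The expected value for compound 3 is 520 nM, with an estimated range from 230 nM to 1200 nM.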

Compound 3, half-maximal inhibitory concentration: 370 nM
Beside the measured number, compound 3's estimate is 1.4-fold (0.15 log units) above it; the measured number falls inside the stated range.
By their numbers in this assay, from the lowest: compounds 3, 1 and 2 (each within the scatter of the next).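

In this assay the series now has its first pairs that differ in one place. Methoxy in place of hydrogen on an aromatic carbon, para to a large group, gives a 1.6-fold lower number from compound 2 to compound 3 (0.20 log units; within the scatter); with trifluoromethyl held fixed, the change from phenylsulfonyl to (4-methoxyphenyl)sulfonyl therefore yields a step that stays inside the scatter. Trifluoromethyl in place of fluoro on an aromatic carbon, with (4-methoxyphenyl)sulfonyl held fixed, gives a 1.3-fold lower number from compound 1 to compound 3 (0.10 log units; within the scatter), so neither single change yet shows a step beyond the scatter, and no measurement is at hand that speaks to the reason for these small steps.

On these data alone, whether an amine, a carboxylic acid or a longer chain such as butoxy in the place of methoxy would give a step beyond the scatter stays open. Also open is whether methoxy in place of hydrogen gives a step of similar size when fluoro rather than trifluoromethyl is present, since the compounds shown read that change only with trifluoromethyl.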